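The source may report more compounds than this note shows. Statements on the series, on what has been measured and on what is new or still open speak of the compounds shown alone.

Three analogues of the shared core have been run in an assay on mitochondria (strain BALB/c) for inhibition of glycerol-3-phosphate acyltransferase 1, mitochondrial (Mus musculus), read by scintillation counting, with a stated time of 10 min; on this read-out higher numbers stand for weaker inhibition and lower numbers for stronger inhibition. Compound 1 `CCCCCCCCS(=O)(=O)Nc1cc(-c2cccc(Cl)c2)ccc1C(=O)O` gives 13800 nM and compound 2 `CCCCCCCCS(=O)(=O)Nc1ccc(-c2ccccc2-c2ccccc2)cc1C(=O)O` gives 10100 nM. Compound 3 `CCCCCCCCS(=O)(=O)Nc1ccc(-c2ccccc2F)cc1C(=O)O` gives 34600 nM and stands weakest of the three, its nearest neighbour being compound 1. Among the measured compounds shown here, the only single-point step in hand is a 3.4-fold higher number from compound 2 to compound 3 (0.53 log units; beyond the scatter): the smaller group on that aromatic carbon goes with the higher number. Compound 4 `CCCCCCCCS(=O)(=O)Nc1ccc(CCc2ccc(OC)cc2)cc1C(=O)O` differs from compound 3 by 2-(4-methoxyphenyl)ethyl in place of 2-fluorophenyl on an aromatic carbon. For the measured compounds named here, the entering group is the larger one, the reverse sense of the measured step, so a lower number is expected; the ring here sits on an ethyl link, which no measured pair covers, and one step is a thin basis. Compound 4 is therefore expected near 15000 nM, with a range of 5000 nM to 45000 nM. That estimate means a 2.3-fold lower number from compound 3 to compound 4 (0.36 log units; beyond the scatter).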

Compound 4, half-maximal inhibitory concentration: 26300 nM
Compound 4: the middle estimate sits 1.8-fold (0.24 log units) below what was measured; the measured number falls inside the stated range.
By their numbers in this assay, from the lowest: compounds 2, 1, 4 and 3 (each within the scatter of the next, the first and the last beyond it).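

The step from 2-fluorophenyl to 2-(4-methoxyphenyl)ethyl is a 1.3-fold lower number from compound 3 to compound 4 (0.12 log units; within the scatter) in this assay, so more heavy atoms on this aromatic carbon do not by themselves go with a lower number. The size link suggested by a 3.4-fold higher number from compound 2 to compound 3 (0.53 log units; beyond the scatter) therefore does not extend to compound 4, which goes against it. No supporting evidence bears on this result.

The compounds shown leave open whether the ethyl link and the methoxy group each matter at this position. On these data alone, how an amine or a carboxylic acid on the entering ring would read also remains open.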